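Chalcone series on prostate carcinoma cells: a halogen swap

This account rests on a few compounds, and the source may have more. Where it says the series, first, only, none or still open, it means among the compounds named here.

Compound 1 `O=C(COc1ccc(C(=O)/C=C/c2ccc(F)c(F)c2)cc1)N[C@H]1CCOC1=O` carries a 3,4-difluorophenyl on the chain of its chalcone portion. Among the measured compounds shown here, in a functional assay on PC-3 cells (Homo sapiens) for antiproliferative activity, read by MTT assay, with a stated time of 72 h (a higher number here means a weaker inhibitor, a lower number a stronger inhibitor), compound 1 gives 21900 nM, the only number in this set. Compound 2 `O=C(CNc1ccc(Cl)cc1Cl)N[C@H]1CCOC1=O`, which lacks the chalcone portion and holds a 2,4-dichloroanilino group instead, gives in this assay only a limit, > 64000 nM, so no number is known for it. For the measured compounds named here, compound 1 therefore stands as the one compound with a measured value, with compound 2 at the limit noted in the evidence (the limit of > 64000 nM in this assay, at which 1 of the 2 values shown sits).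

Compound 3 `O=C(COc1ccc(C(=O)/C=C/c2ccc(Br)cc2)cc1)N[C@H]1CCOC1=O` is not yet measured. It differs from compound 1 in one place: 4-bromophenyl in place of 3,4-difluorophenyl on a double-bonded chain carbon bound to a double-bonded chain carbon. Going by the values given here, no step between measured compounds of this kind is available, so there is nothing to calibrate the size of this change against. The expectation is that the step from compound 1 to compound 3 in this assay stays within the usual scatter, with no clear direction, which is what a 1.1-fold lower number from compound 1 to compound 3 (0.04 log units; within the scatter) expresses. Compound 3 is accordingly estimated at 20000 nM in this assay, within 7000 nM to 55000 nM.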

Compound 3, half-maximal inhibitory concentration: > 64000 nM
Compound 3: only a limit was reported; the forecaster's own chance of this, stated with the estimate: 15%; middle value at least 3.2-fold (0.50 log units) from the limit.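

In this assay compound 3 gives only a limit, > 64000 nM, and not a number. Among the compounds shown here, replacing 3,4-difluorophenyl with 4-bromophenyl on a double-bonded chain carbon bound to a double-bonded chain carbon gives an at least 2.9-fold higher number from compound 1 to compound 3 (0.46 log units; beyond the scatter), the first step that can be read, so this position is not indifferent to the aryl group it carries and the activity of compound 1 does not survive every halogen exchange there. The true size of the step remains unknown in the upward direction, and limits now account for most of the series: the limit of > 64000 nM in this assay, at which 2 of the 3 values shown sit.

The change alters both the halogen and the number of halogens, so the compounds shown do not separate the gain of bromine from the loss of the two fluorines. A 4-fluorophenyl group at the same place would pull these two apart, and a 4-methoxyphenyl or 4-aminophenyl group would show whether anything other than a halogen is accepted there.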